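Methyl in Place of Fluoro: An Expected Step

The source may report more compounds than this note shows. Statements on the series, on what has been measured and on what is new or still open speak of the compounds shown alone.

Measured compounds:
- compound 1, `Clc1ccc(-c2csc(N/N=C/c3cccs3)n2)cc1`, 94.4%
- compound 2, `Fc1ccc(-c2csc(N/N=C/c3ccc(Cl)cc3Cl)n2)cc1`, 90.7%

In a functional assay, read by spectrophotometry, with a stated time of 15 min, tested at 20 ug/mL (a lower number here means a weaker effect, a higher number a stronger effect of the compound at the concentration tested), compound 1 gives 94.4%, and compound 2 gives 90.7%. Compound 2 stands lowest of the two numbers, yet its nearest neighbour, compound 1, lies only a little higher, a gap within the usual scatter, so the two values cannot be told apart; both sit high. The two measured compounds differ in more than one place. Among the compounds with values here, no single step between them can be read off.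

Compound 3, `Cc1ccc(-c2csc(N/N=C/c3ccc(Cl)cc3Cl)n2)cc1`, differs from compound 2 in one place: methyl in place of fluoro on an aromatic carbon. The change sits on an aromatic carbon of a six-membered aromatic ring of carbon only.

Within the data shown here, with no measured step of the same kind to lean on, the expectation rests on how high both measured values already stand. A step of a number 0.7 percentage points lower from compound 2 to compound 3 (within the scatter) is expected, that is, none beyond the scatter, in either direction. Compound 3 is therefore estimated at 90% in this assay, with a range from 78% to 97%.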

Compound 3, a percentage reported as inhibition, at one concentration (the size of the read-out at that concentration, not a potency): 86%
Compound 3: the middle estimate sits 4 percentage points above what was measured; low and high end bracket the measured number.
By their numbers in this assay, from the lowest: compounds 3, 2 and 1 (each within the scatter of the next).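

Within the data shown here, this is the first comparison that changes a single place, and it shows what happens at the 4-position of the phenyl ring when 4-fluorophenyl becomes 4-methylphenyl. In this assay, methyl in place of fluoro gives a number 4.7 percentage points lower from compound 2 to compound 3 (within the scatter), so the two compounds cannot be told apart, and this position, para to a large group, accepts either of these one-atom groups without a change beyond the usual scatter. The compounds shown offer no measurement that could explain this result.

On these data alone, the read-out comes from a single concentration and is not a potency, so any difference in potency between compound 2 and compound 3 remains unknown, and compound 1 differs from both in more than one place, leaving its steps to them unreadable. Also open, as far as these compounds go, is whether this position would accept a group of a quite different kind, such as an amine, a carboxylic acid or a longer chain like butyl, with the number staying within the scatter of compound 2.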